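Working notes: stereo-undefined analogue of compound 2

The compounds below may be only part of what the source reports. "The series", "measured", "known", "first", "only" and "open" are said of these compounds alone.

Measured so far:
compound 1 `CC(C)C[C@]1(O)NC(=O)[C@]2(OC(Cc3ccccc3)=CC2=O)[C@H]1O`: > 50000 nM
compound 2 `CC1=CC(=O)[C@]2(O[C@@H]2C(=O)CC(C)C)C(=O)N1`: "not determined" (no result reported)

The only read-out on this series is a functional assay on Jurkat cells (Homo sapiens) for cytotoxicity, read by WST assay, with a stated time of 48 h; on this read-out higher numbers stand for weaker inhibition and lower numbers for stronger inhibition. Among the compounds with values here, compound 1 gives only a limit in this assay, > 50000 nM, and the limit line the limit of > 50000 nM in this assay, at which 1 of the 2 values shown sits, is the sole piece of evidence available. Compound 2 is recorded in this assay as "not determined" (no result reported), so there is no number for it to stand on, and the pair compound 1 and compound 2 is not a single-change pair, so nothing is said about a step between them.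

Compound 3 `CC1=CC(=O)C2(OC2C(=O)CC(C)C)C(=O)N1` is the next entry. How it differs from compound 2: the two compounds have the same atoms and bonds; at least one stereo element is drawn with a configuration in one of them and without one in the other: 2 of 2 stereo elements differ; a stereocentre at a saturated ring carbon is drawn S in compound 2 and without a configuration in compound 3; a stereocentre at a saturated ring carbon is drawn S in compound 2 and without a configuration in compound 3. With the same atoms and bonds, no step beyond the scatter is expected in this assay for compound 3 relative to compound 2, in either direction. Given that the only measurement so far is a limit, compound 3 is estimated at 40000 nM, with a range of 5000 nM to 200000 nM, and a limit is likely to be reported again.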

Compound 3, half-maximal inhibitory concentration: 8000 nM
Compound 3: middle estimate off by 5.0-fold (0.70 log units), on the high side; low and high end bracket the measured number.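

In this assay compound 2 is recorded as "not determined" (no result reported) and compound 3 gives 8000 nM so no step can be read between these two compounds. As far as these compounds go, whether the configuration drawn at the two saturated ring carbons shifts the result in this assay at all stays open.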